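Cytotoxicity notes: acetyl in place of benzoxazolyl

This account rests on a few compounds, and the source may have more. Where it says the series, first, only, none or still open, it means among the compounds named here.

Three members of the series have been through a toxicity assay on NIH3T3 cells (Mus musculus) for cytotoxicity, read by resazurin assay (on this read-out lower numbers stand for an effect already at smaller amounts and higher numbers for an effect only at larger amounts of compound), so far. Compound 1 `Cc1cccc(-c2cccc(NCc3cncn3Cc3ccccc3)c2)c1C` returns a limit, > 1000 nM, and no number. Compound 2 `COC(=O)c1ccc(NCc2cncn2Cc2ccccc2OC)cc1-c1ccccc1` has no result recorded in this assay, "not determined" (no result reported). Compound 3 `c1ccc(-c2ccc(Cn3cncc3CNc3ccc(-c4nc5ccccc5o4)c(-c4ccccc4)c3)cc2)cc1` also returns a limit in this assay, > 10000 nM. Among the three entries, compound 3 therefore stands at the higher of the two limits reached: one further value sits at the limit of > 1000 nM in this assay, at which 1 of the 3 values shown sits, compound 3 alone sits at the limit of > 10000 nM in this assay, at which 1 of the 3 values shown sits, and the remaining entry carries no number at all. Among the measured compounds shown here, no two measured compounds differ in a single place, so no measured step is available to lean on.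

Compound 4 `CC(=O)c1ccc(NCc2cncn2Cc2ccc(-c3ccccc3)cc2)cc1-c1ccccc1` is the next member for this assay. Its change from compound 3 is acetyl in place of 1,3-benzoxazol-2-yl on an aromatic carbon. Because compound 3 in this assay gives only > 10000 nM, there is no measured number from which a shift could be read. In this assay the expected step is a step that the limit leaves unreadable from compound 3 to compound 4, that is, nothing beyond the usual scatter. Compound 4 is accordingly estimated at 20000 nM, within a range from 5000 nM to 80000 nM, most likely reported again as a limit.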

Compound 4, half-maximal effective concentration: > 10000 nM
Compound 4 ended at the assay's limit; the forecaster's own chance of this, stated with the estimate: 80%; the middle value is on the limit's open side.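

Among the compounds shown here, compound 3 and compound 4 both stop at a limit in this assay and not at a number, and no step between them can be read. The compounds shown leave open whether acetyl in place of 1,3-benzoxazol-2-yl changes cytotoxicity at all, and at what concentration any of them would reach a half-maximal effect.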